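The source may report more compounds than this note shows. Statements on the series, on what has been measured and on what is new or still open speak of the compounds shown alone.

Values measured in a functional assay on NCI-H460 cells (Homo sapiens) for cytotoxicity, read by MTT assay, with a stated time of 48 h; on this read-out lower numbers stand for stronger inhibition of growth and higher numbers for weaker inhibition of growth:
Compound 1 `O=C1Nc2ccccc2/C1=N/NC(=S)N1CCN(C(=O)NO)CC1`: > 100000 nM, a limit of the assay
Compound 2 `O=C(NO)N1CCN(C(=S)N/N=C/c2ccccc2O)CC1`: 5150 nM
Compound 3 `O=C(NO)N1CCN(C(=S)N/N=C/c2ccccc2Cl)CC1`: 30000 nM

Among the compounds with values here, compound 3, with 30000 nM, holds the higher of the two actual numbers, and compound 2 is its only numerical neighbour. Compound 1 sits at the limit of > 100000 nM in this assay, at which 1 of the 3 values shown sits.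

Compound 4 `Cc1ccc(/C=N/NC(=S)N2CCN(C(=O)NO)CC2)cc1` has not been measured. It differs from compound 3 as follows: 4-methylphenyl in place of 2-chlorophenyl on a carbon with a double bond to nitrogen. Within the data shown here, only one measured step bears on this change, a 5.8-fold higher number from compound 2 to compound 3 (0.77 log units; beyond the scatter), which is modest and concerns a different swap. A step of similar or smaller size is therefore expected in this assay, with no firm direction. For compound 4 the estimated value is 20000 nM, with an expected range of 6000 nM to 70000 nM. This estimate means an expected 1.5-fold lower number from compound 3 to compound 4 (0.18 log units; within the scatter).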

Compound 4, concentration for 50% growth inhibition: 51000 nM
Estimate against measurement, compound 4: 2.6-fold (0.41 log units) below; the measured number falls inside the stated range.
By their numbers in this assay, from the lowest: compound 2; then compounds 3 and 4 (each within the scatter of the next). At a limit, above all of these: compound 1.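

In this assay the change on a carbon with a double bond to nitrogen gives a 1.7-fold higher number from compound 3 to compound 4 (0.23 log units; within the scatter) and so does not separate 4-methylphenyl from 2-chlorophenyl. The step of a 9.9-fold higher number from compound 2 to compound 4 (1.00 log units; beyond the scatter) sets 2-hydroxyphenyl apart from 4-methylphenyl, as it already stood apart from 2-chlorophenyl, so compound 2 keeps the lowest number against two different replacements. Nothing measured here accounts for these steps. Still open, going by these compounds, is whether an amine or a methoxy group on the phenyl ring would match compound 2, and whether hydroxy would do so elsewhere on that ring.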